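Shortening the acyl chain on a cytotoxic amide core

The compounds below may be only part of what the source reports. "The series", "measured", "known", "first", "only" and "open" are said of these compounds alone.

Measured compounds:
compound 1, `CCCCCCCCC(=O)N1c2ccccc2CCC1C(=O)Nc1ccccc1C(F)(F)F`: 8330 nM
compound 2, `COc1ccc(NC(=O)C2CCc3ccccc3N2)cc1`: 38000 nM
compound 3, `CCCCCCCCC(=O)N1c2ccccc2CCC1C(=O)Nc1ccccc1O`: 65000 nM

In a functional assay on ACHN cells (Homo sapiens) for cytotoxicity, read by sulforhodamine B assay, with a stated time of 72 h (a higher number here means a weaker inhibitor of growth, a lower number a stronger inhibitor of growth), compound 1 gives the lowest of the three numbers; compound 2 lies 38000 nM and compound 3 65000 nM, both beyond the scatter from it. Going by the values given here, the only single-point step measured so far, a 7.8-fold higher number from compound 1 to compound 3 (0.89 log units; beyond the scatter), concerns the aromatic substituent of the amide and not the acyl group on the ring nitrogen.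

Compound 4, `CC(=O)N1c2ccccc2CCC1C(=O)Nc1ccccc1C(F)(F)F`, keeps the trifluoromethyl and changes only the acyl group: hydrogen in place of heptyl on a saturated chain carbon bound to a carbonyl carbon. Among the compounds with values here, no measured pair isolates this change. Compound 2 carries no acyl group at all and differs from compound 1 in a second place as well, so its value can only hint that removing the octylcarbonyl does not make the number smaller. Compound 4 is therefore expected to give a higher number than compound 1, a 3.6-fold higher number from compound 1 to compound 4 (0.56 log units; beyond the scatter), with an estimate of 30000 nM and a range from 8000 nM to 110000 nM.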

Compound 4, concentration for 50% growth inhibition: > 80000 nM
Compound 4: no number, only a limit (the forecaster's own chance of this, stated with the estimate: 25%); at least 2.6-fold (0.42 log units) between middle value and limit.
By their numbers in this assay, from the lowest: compound 1; then compounds 2 and 3 (each within the scatter of the next). At a limit, above all of these: compound 4.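

In this assay compound 4 gives only a limit and not a number, > 80000 nM. Going by these compounds alone, this is the first measured pair to isolate the acyl group: with the trifluoromethyl held fixed, octylcarbonyl to acetyl gives an at least 9.6-fold higher number from compound 1 to compound 4 (0.98 log units; beyond the scatter), so the growth inhibition of compound 1 depends on this chain as well as on the aromatic substituent of the amide. The size of this step is bounded on one side only, and its full extent cannot be read: the limit of > 80000 nM in this assay, at which 1 of the 4 values shown sits.

From the compounds shown here alone, whether a butyl or hexyl chain on the carbonyl would keep the number of compound 1, or a longer chain such as dodecyl would lower it, remains open. Also open, going by these compounds, is whether an amine or a carboxylic acid carried on the octyl chain would keep that number.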